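Replacing a Chlorophenyl Group on the Sulfonyl Sulfur

The compounds below may be only part of what the source reports. "The series", "measured", "known", "first", "only" and "open" are said of these compounds alone.

Of the compounds shown here, two have been measured in a functional assay on PC-3 cells (Homo sapiens) for inhibition, read by MTT assay, with a stated time of 48 h; a lower number here means a stronger inhibitor, a higher number a weaker inhibitor. Compound 1 `COc1cc(N(Cc2nc3ccccc3[nH]2)S(=O)(=O)c2ccc(C)cc2)cc(OC)c1OC` gives 3340 nM in this assay. Compound 2 `COc1cc(N(Cc2nc3ccccc3[nH]2)S(=O)(=O)c2ccccc2Cl)cc(OC)c1OC` gives 34500 nM in this assay, the highest of the two numbers, and the step of a 10-fold higher number from compound 1 to compound 2 (1.01 log units; beyond the scatter) is the only one measured so far. Compound 3 `COc1ccc(S(=O)(=O)N(Cc2nc3ccccc3[nH]2)c2cc(OC)c(OC)c(OC)c2)cc1OC` has not been measured. It differs from compound 2 in one place: 3,4-dimethoxyphenyl in place of 2-chlorophenyl on a sulfonyl sulfur. For the measured compounds named here, no measured step places a 3,4-dimethoxyphenyl group on this sulfur, so the single step in the set is the only guide, and it shows that the group on the sulfonyl sulfur matters greatly: moving from the 4-methylphenyl group to the 2-chlorophenyl group was a large step upward. Because the step of a 10-fold higher number from compound 1 to compound 2 (1.01 log units; beyond the scatter) was large, a sizeable move back downward is expected once the 2-chlorophenyl group is removed, though with much uncertainty about where the new group lands, so compound 3 is expected to show a 5.8-fold lower number from compound 2 to compound 3 (0.76 log units; beyond the scatter). Compound 3 is therefore estimated at 6000 nM, with a range from 1500 nM to 30000 nM.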

Compound 3, half-maximal inhibitory concentration: 30400 nM
Beside the measured number, compound 3's estimate is 5.1-fold (0.70 log units) below it; the whole stated range lies below it.
By their numbers in this assay, from the lowest: compound 1; then compounds 3 and 2 (each within the scatter of the next).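

Placing a 3,4-dimethoxyphenyl group on the sulfonyl sulfur in place of 2-chlorophenyl gives a 1.1-fold lower number from compound 2 to compound 3 (0.05 log units; within the scatter), so this assay does not tell these two groups apart, even though the entering group has more heavy atoms and carries hydrogen-bond acceptors that the leaving group lacks. Set against the 4-methylphenyl group, the same change gives a 9.1-fold higher number from compound 1 to compound 3 (0.96 log units; beyond the scatter), so two quite different groups now stand together, and among these three compounds only compound 1 has the clearly lower number. Nothing measured here explains why the 4-methylphenyl group stands apart from the other two.

What the compounds shown leave open is which feature of the 4-methylphenyl group goes with its lower number: a plain phenyl, a 4-chlorophenyl or a 4-methoxyphenyl group on this sulfur would each bear on that question. Also open, from the compounds shown here alone, is whether an aromatic ring is needed on the sulfonyl sulfur at all, which a simple methyl group or a longer alkyl chain in its place would test.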